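The source may report more compounds than this note shows. Statements on the series, on what has been measured and on what is new or still open speak of the compounds shown alone.

In a functional assay on A549 cells (Homo sapiens) for inhibition, read by sulforhodamine B assay, with a stated time of 48 h (a lower number here means that less compound is tolerated, a higher number that more compound is tolerated), compound 3 `COc1ccc(C(=O)/C=C/c2cc(-c3cc(OC)c(OC)c(OC)c3)n[nH]2)cc1OC` gives 15700 nM, the lowest of the two numbers recorded here. Compound 2 `COc1ccc(-c2cc(/C=C/C(=O)c3cc(OC)c(OC)c(OC)c3)[nH]n2)cc1OC` gives 62400 nM in this assay, a number beyond the scatter above that of compound 3. Compound 1 `COc1cc(-c2cc(/C=C/C(=O)c3ccc(Cl)c(Cl)c3)[nH]n2)cc(OC)c1OC` reaches only the limit > 100000 nM in this assay. Going by the values given here, the single one-place step, an at least 6.3-fold lower number from compound 1 to compound 3 (0.80 log units; beyond the scatter), is bounded only because of the limit of > 100000 nM in this assay, at which 1 of the 3 values shown sits, and it concerns the whole aryl group on the carbonyl carbon, not an added methoxy. Compound 4 `COc1cc(C(=O)/C=C/c2cc(-c3cc(OC)c(OC)c(OC)c3)n[nH]2)cc(OC)c1OC` differs from compound 3 by methoxy in place of hydrogen on an aromatic carbon. Among the compounds with values here, no measured step tracks such a change, so no shift beyond the scatter is expected, and the estimate is a 1.0-fold lower number from compound 3 to compound 4 (0.02 log units; within the scatter). Compound 4 is accordingly expected at 15000 nM, within 5000 nM to 50000 nM.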

Compound 4, concentration lethal to 50% of the cells: 59200 nM
Compound 4: middle estimate off by 3.9-fold (0.60 log units), on the low side, and the stated range ends below it.
By their numbers in this assay, from the lowest: compound 3; then compounds 4 and 2 (each within the scatter of the next). At a limit, above all of these: compound 1.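

In this assay methoxy in place of hydrogen on the aromatic ring on the carbonyl carbon gives a 3.8-fold higher number from compound 3 to compound 4 (0.58 log units; beyond the scatter) while the same change on the other aromatic ring gives a 1.1-fold lower number from compound 2 to compound 4 (0.02 log units; within the scatter) and so, in these two pairs, the outcome depends on which ring carries the new methoxy. Each ring is represented by a single pair, so this is no general rule.

As far as these compounds go, whether a hydroxyl or an amine at this position would give a number closer to that of compound 3 or compound 4 remains open. Nothing given here accounts for the difference between the two steps.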